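A few compounds are considered here, and "the series" means these few. Any claim that something is new, unique, unknown or untested is made for them only; others in the source may bear on it.

Measured compounds:
Compound 1, `Ic1ccc(Cn2cc(CCCOc3cccc4cccnc34)nn2)cc1`, gives 22.6 ug/mL in a functional assay on 786-0 cells (Homo sapiens) for inhibition, read by sulforhodamine B assay, with a stated time of 48 h; on this read-out lower numbers stand for stronger inhibition of growth and higher numbers for weaker inhibition of growth.
Compound 2, `Clc1ccc(Br)cc1Cn1cc(CCCOc2cccc3cccnc23)nn1`, gives only a limit, > 250 ug/mL, in this assay.

Compound 2 therefore stands at the weak end of the two measured compounds: it is defined by the limit of > 250 ug/mL in this assay, at which 1 of the 2 values shown sits, rather than by a number, so it cannot be placed more precisely than that. Among the compounds with values here, the single measured step, an at least 11-fold higher number from compound 1 to compound 2 (1.04 log units; beyond the scatter), shows that moving from 4-iodophenyl to 5-bromo-2-chlorophenyl on the saturated chain carbon bound to the aromatic nitrogen pushed the result out of range.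

Compound 3, `c1ccc(Cn2cc(CCCOc3cccc4cccnc34)nn2)cc1`, removes both halogens from that ring: phenyl in place of 5-bromo-2-chlorophenyl on a saturated chain carbon bound to an aromatic nitrogen. Within the data shown here, no measured step covers exactly this change, so the expectation rests on the only step available. Because an at least 11-fold higher number from compound 1 to compound 2 (1.04 log units; beyond the scatter) shows a halogenated ring moving from a measurable number to a limit, the plain phenyl of compound 3 is expected to fall back into the measurable range, giving an expected step of an at least 4.1-fold lower number from compound 2 to compound 3 (0.61 log units; beyond the scatter). Compound 3 is therefore estimated at 60 ug/mL, with a likely range from 20 ug/mL to 250 ug/mL.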

Compound 3, concentration for 50% growth inhibition: 25 ug/mL
Estimate against measurement, compound 3: 2.4-fold (0.38 log units) above; measured number inside the range.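

Removing both halogens restores a measurable number in this assay, with an at least 10-fold lower number from compound 2 to compound 3 (1.00 log units; beyond the scatter), so the shared core with an unsubstituted benzyl group does not by itself put a compound out of range, and the loss seen in compound 2 goes with the 5-bromo-2-chlorobenzyl group. The reading for compound 2 is a limit and not a number, so this step has only a minimum size: the limit of > 250 ug/mL in this assay, at which 1 of the 3 values shown sits. A halogen on this ring does not always go with that loss, and compound 1 is the counterexample: hydrogen in place of iodo on an aromatic carbon gives a 1.1-fold higher number from compound 1 to compound 3 (0.04 log units; within the scatter), a step within the scatter, so compound 1 and compound 3 cannot be told apart.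

Still open, as far as these compounds go, is whether the bromo, the chloro or the two together account for the loss, as none of the three compounds carries a ring with only one of them. Also open, from the compounds shown here alone, is how a phenyl ring bearing an amine or a carboxylic acid, or a longer chain at this place, would read in this assay.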